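The compounds below may be only part of what the source reports. "The series", "measured", "known", "first", "only" and "open" are said of these compounds alone.

Working notes on the series.

Going by the values given here, compound 1 `CCCCNC(=O)NCc1ccc(CCCC)n(Cc2ccc(-c3ccccc3-c3nn[nH]n3)cc2)c1=O` sits second highest of the three numbers so far in a functional assay (aorta) for antagonist activity, with Oryctolagus cuniculus as the target (on this read-out lower numbers stand for stronger inhibition and higher numbers for weaker inhibition), where compound 1 gives 10 nM. Compound 2 `CCCCc1ccc(CNS(=O)(=O)c2ccc(C)cc2)c(=O)n1Cc1ccc(-c2ccccc2-c2nn[nH]n2)cc1` gives 9 nM, and the step of a 1.1-fold lower number from compound 1 to compound 2 (0.05 log units; within the scatter) keeps the two within the scatter. Compound 3 `CCCCc1ccc(CN(Cc2ccccc2)S(=O)(=O)c2ccc(C)cc2)c(=O)n1Cc1ccc(-c2ccccc2-c2nn[nH]n2)cc1` gives 60 nM, the step of a 6.7-fold higher number from compound 2 to compound 3 (0.82 log units; beyond the scatter) lying beyond the scatter.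

Compound 4 `CCCCc1ccc(CN(Cc2ccccc2)S(C)(=O)=O)c(=O)n1Cc1ccc(-c2ccccc2-c2nn[nH]n2)cc1` is not yet measured. Against compound 1 the change is benzyl(methylsulfonyl)amino in place of (butylcarbamoyl)amino on a saturated chain carbon bound to an aromatic carbon. Among the compounds with values here, two measured steps bear on it. Exchange of the carbamoyl for a sulfonyl group on the same nitrogen, as in the step from compound 1 to compound 2, left the number within the scatter. Putting benzyl in place of hydrogen on the sulfonamide nitrogen, as in the step from compound 2 to compound 3, raised the number modestly. Within the data shown here, compound 4 carries methylsulfonyl rather than (4-methylphenyl)sulfonyl, and no pair so far shows what that exchange does; compounds 3 and 4 share the benzyl on the sulfonamide nitrogen.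

The expected step is therefore a modest rise, a 6.0-fold higher number from compound 1 to compound 4 (0.78 log units; beyond the scatter), as seen from compound 2 to compound 3. Compound 4 is estimated at 60 nM in this assay, with a range of 20 nM to 200 nM.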

Compound 4, half-maximal inhibitory concentration: 2 nM
Compound 4: the middle estimate sits 30-fold (1.48 log units) above what was measured, and the stated range ends above it.
By their numbers in this assay, from the lowest: compound 4; then compounds 2 and 1 (each within the scatter of the next); then compound 3.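

Going by these compounds alone, on the sulfonyl sulfur, methyl in place of 4-methylphenyl gives a 30-fold lower number from compound 3 to compound 4 (1.48 log units; beyond the scatter) in this assay, the first sign that the group on sulfur can strongly change the number when benzyl sits on the sulfonamide nitrogen. The rise that came with benzyl on the toluenesulfonamide therefore does not carry over to every sulfonyl partner, and benzyl(methylsulfonyl)amino on a saturated chain carbon bound to an aromatic carbon gives the lowest number of the series, with a 5.0-fold lower number from compound 1 to compound 4 (0.70 log units; beyond the scatter) and a 4.5-fold lower number from compound 2 to compound 4 (0.65 log units; beyond the scatter). Nothing available explains the size or direction of these steps.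

As far as these compounds go, what benzyl itself contributes alongside methylsulfonyl stays open, as that reading needs a partner with methylsulfonyl and hydrogen on the sulfonamide nitrogen. Also open, from the compounds shown here alone, is whether ethyl, propyl or trifluoromethyl on the sulfonyl sulfur, or a 4-methoxybenzyl or a simple methyl on the sulfonamide nitrogen, would hold the number near that of compound 4 or move it back towards that of compound 3.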